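Removing One Chloro Group from Compound 2

This account rests on a few compounds, and the source may have more. Where it says the series, first, only, none or still open, it means among the compounds named here.

Measured so far:
compound 1 `ClCc1cccc(Cn2cnc3ncnc(Cl)c32)c1`: 1770 nM
compound 2 `ClCc1ccc(Cn2cnc3nc(Cl)nc(Cl)c32)cc1`: 300 nM

In a functional assay on OVCAR-3 cells (Homo sapiens) for cytotoxicity, read by sulforhodamine B assay, with a stated time of 48 h (on this read-out lower numbers stand for stronger inhibition of growth and higher numbers for weaker inhibition of growth), compound 2 gives 300 nM, the lower of the two numbers, while compound 1 gives 1770 nM, a gap beyond the scatter. Compound 3 `ClCc1ccc(Cn2cnc3ncnc(Cl)c32)cc1` differs from compound 2 in one place: hydrogen in place of chloro on an aromatic carbon. Going by the values given here, no measured pair shows this change on its own, so its effect is unknown. Compound 3 is expected to inhibit growth somewhat less strongly than compound 2, with an estimated step of a 3.0-fold higher number from compound 2 to compound 3 (0.48 log units; beyond the scatter) beyond the scatter. The estimated value for compound 3 in this assay is 900 nM, within a range of 300 nM to 2700 nM.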

Compound 3, concentration for 50% growth inhibition: 1810 nM
Estimate against measurement, compound 3: 2.0-fold (0.30 log units) below; the range from low to high includes it.
By their numbers in this assay, from the lowest: compound 2; then compounds 1 and 3 (each within the scatter of the next).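

In this assay, going by these compounds alone, replacing the chloro group between two ring nitrogen atoms with hydrogen gives a 6.0-fold higher number from compound 2 to compound 3 (0.78 log units; beyond the scatter) and so provides the first direct reading of this change. At this position, the chloro group contributes to the stronger growth inhibition of compound 2, at least on this shared core. Nothing at hand gives a cause for this step. Going by these compounds, whether an amine or a methoxy group at the same position would match chloro or fall back towards hydrogen remains open.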